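The compounds below may be only part of what the source reports. "The series", "measured", "known", "first", "only" and "open" are said of these compounds alone.

Of the compounds shown here, three built on one shared core have so far been measured in a functional assay on DU-145 cells (Homo sapiens) for cytotoxicity, read by MTT assay, with a stated time of 48 h; a higher number here means a weaker inhibitor, a lower number a stronger inhibitor. Compound 1 `CCOC(=O)c1c(-c2cc3ccccc3oc2=O)nn(-c2cccc(C)c2)c1C(=O)OCC` gives 47000 nM, compound 2 `CCOC(=O)c1c(-c2cc3ccccc3oc2=O)nn(-c2ccc(C)c(C)c2)c1C(=O)OCC` gives 40000 nM, and compound 3 `CCOC(=O)c1c(-c2cc3ccccc3oc2=O)nn(-c2cccc(F)c2)c1C(=O)OCC` gives 32000 nM. Compound 3 gives the smallest of the three numbers, yet it does not stand apart from its neighbours: a 1.3-fold lower number from compound 2 to compound 3 (0.10 log units; within the scatter) and a 1.5-fold lower number from compound 1 to compound 3 (0.17 log units; within the scatter). The remaining pair behaves the same way, since a 1.2-fold lower number from compound 1 to compound 2 (0.07 log units; within the scatter).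

Compound 4 `CCOC(=O)c1c(-c2cc3ccccc3oc2=O)nn(-c2ccc(Cl)cc2)c1C(=O)OCC` has not yet been measured. It differs from compound 3 in one place: 4-chlorophenyl in place of 3-fluorophenyl on an aromatic nitrogen. Every step measured so far alters this same aryl group on the aromatic nitrogen, whether by adding a methyl, by exchanging a methyl for a fluoro, or by replacing one whole aryl with another, and none of those steps carried the number beyond the scatter. With nothing in the measured set pointing either way, the chemist expects the same here: compound 4 is expected to show a 1.1-fold higher number from compound 3 to compound 4 (0.04 log units; within the scatter) in this assay, that is, no step beyond the scatter. Compound 4 is therefore estimated at 35000 nM, with a range running from 17000 nM to 70000 nM.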

Compound 4, half-maximal inhibitory concentration: 26000 nM
The estimate for compound 4 lay 1.3-fold (0.13 log units) above the measured number; the range from low to high includes it.
By their numbers in this assay, from the lowest: compounds 4, 3, 2 and 1 (each within the scatter of the next).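

The chloro-bearing aryl is new to the set, and it extends what the aromatic nitrogen next to the ring nitrogen has been shown to accept in this assay: the exchange of 3-fluorophenyl for 4-chlorophenyl changes both the halogen and where it sits on the aryl ring, yet the step stays small (a 1.2-fold lower number from compound 3 to compound 4 (0.09 log units; within the scatter)). The comparisons with the two methyl-bearing aryls read the same way (a 1.5-fold lower number from compound 2 to compound 4 (0.19 log units; within the scatter); a 1.8-fold lower number from compound 1 to compound 4 (0.26 log units; within the scatter)), so even the largest step yet seen at this position does not leave the scatter, and the four aryl groups remain unseparated. No evidence on the origin of these small differences accompanies the numbers.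

Since the step from compound 3 to compound 4 combines two changes, their separate contributions remain unresolved, and 4-fluorophenyl and 3-chlorophenyl would be the groups to separate them. Also open, going by these compounds, is whether an aryl bearing an amine, a carboxylic acid or a methoxy group, or a longer chain in place of the ethoxycarbonyl groups on the shared core, would move the number beyond the scatter.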